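Side-chain variation at the carbonyl-bound oxygen

The source may hold more compounds than are shown below. What is called first, only, known or untested is meant among the compounds shown, and "the series" means these compounds.

Two compounds of the series carry numbers in an in vitro assay on Sf-9 cells for inhibition of protein kinase C epsilon type (Homo sapiens); a higher number here means a weaker inhibitor, a lower number a stronger inhibitor. Compound 1 `O=C(N[C@@H]1CNC[C@H]1OC(=O)c1cc(O)c(C(=O)c2c(O)cccc2C(=O)OCC2CCCCC2)c(O)c1)c1ccc(O)cc1` gives 25000 nM. Within the data shown here, compound 2 `CC(=O)OCOC(=O)c1cccc(O)c1C(=O)c1c(O)cc(C(=O)O[C@@H]2CNC[C@H]2NC(=O)c2ccc(O)cc2)cc1O` gives 130 nM, the lowest of the two numbers, with compound 1 as its only neighbour at a much higher number. Among the measured compounds shown here, the single measured step, a 190-fold lower number from compound 1 to compound 2 (2.28 log units; beyond the scatter), shows that what sits on the saturated chain carbon bound to an oxygen next to a carbonyl group moves the number strongly.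

Compound 3 `CCOC(=O)c1cccc(O)c1C(=O)c1c(O)cc(C(=O)O[C@@H]2CNC[C@H]2NC(=O)c2ccc(O)cc2)cc1O` varies the same place: methyl in place of acetoxy on a saturated chain carbon bound to an oxygen next to a carbonyl group. For the measured compounds named here, no measured step covers acetoxy against methyl; the step from compound 1 to compound 2 only shows that this place is sensitive. Compound 3 is therefore expected to rise from compound 2 by a 3.1-fold higher number from compound 2 to compound 3 (0.49 log units; beyond the scatter), with wide uncertainty. For compound 3 the estimate in this assay is 400 nM, within the range 80 nM to 3000 nM.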

Compound 3, half-maximal inhibitory concentration: 1300 nM
Compound 3: the middle estimate sits 3.3-fold (0.51 log units) below what was measured, within the range that was stated.
By their numbers in this assay, from the lowest: compound 2; then compound 3; then compound 1.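

In this assay there is a 10-fold higher number from compound 2 to compound 3 (1.00 log units; beyond the scatter) when methyl replaces acetoxy on the saturated chain carbon bound to an oxygen next to a carbonyl group, so sensitivity at this place is now seen for a change that does not involve cyclohexyl. There is also a 19-fold lower number from compound 1 to compound 3 (1.28 log units; beyond the scatter) when methyl replaces cyclohexyl at the same place, which turns a single contrast into an order of three groups: acetoxy with the lowest number, then methyl, then cyclohexyl. No measurement at hand bears on the reason for this order.

The three groups differ in several counts at once, so the compounds shown do not tell which feature of acetoxy goes with the lower number. On these data alone, a longer chain such as propyl and a methoxy group on this carbon remain open, and either would help separate chain length from the oxygens of acetoxy.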